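Removing one methoxy group from compound 2

The compounds below may be only part of what the source reports. "The series", "measured", "known", "first", "only" and "open" are said of these compounds alone.

In a functional assay on cells (Erythrocyte, Rattus norvegicus) for inhibition, read by hemolysis, with a stated time of 1 h (a lower number here means a stronger inhibitor, a higher number a weaker inhibitor), compound 2 `COc1ccc(C(=O)/C=C/c2cc(OC)c(OC)cc2OC)cc1` gives 2.18 ug/mL as its reading. Compound 1 `COc1cc(OC)c(OC)cc1/C=C/C(=O)c1ccc(Cl)cc1` gives 2.3 ug/mL and compound 3 `COc1cc(OC)c(OC)cc1/C=C/C(=O)c1cc(Cc2ccccc2)cc(Cc2ccccc2)c1` gives 2.17 ug/mL in the same test. All three numbers lie within the scatter of one another, so compound 2 stands level with both.

Compound 4 `COc1cc(OC)c(OC)cc1/C=C/C(=O)c1ccccc1` has not yet been measured. It differs from compound 2 by hydrogen in place of methoxy on an aromatic carbon in one place: hydrogen in place of methoxy on an aromatic carbon, para to a large group, so that 4-methoxyphenyl becomes phenyl.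

For the measured compounds named here, the only measured step touching this group is a 1.1-fold lower number from compound 1 to compound 2 (0.02 log units; within the scatter) and lies within the scatter. Going by the values given here, no measured compound carries hydrogen there, so this evidence is indirect. Even so, it gives no reason to expect a change beyond the scatter. The expected step is a 1.1-fold higher number from compound 2 to compound 4 (0.02 log units; within the scatter) and stays within the scatter. In this assay compound 4 is estimated to give 2.3 ug/mL with 1.2 ug/mL to 4.4 ug/mL as its likely range.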

Compound 4, half-maximal inhibitory concentration: 2.23 ug/mL
Compound 4: the middle estimate sits 1.0-fold (0.01 log units) above what was measured; the range from low to high includes it.
By their numbers in this assay, from the lowest: compounds 3, 2, 4 and 1 (each within the scatter of the next).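

With hydrogen at this position, the series now has a reading for the ring with no substituent at all, on an aromatic carbon para to a large group. In this assay, removing the methoxy group gives a 1.0-fold higher number from compound 2 to compound 4 (0.01 log units; within the scatter), and replacing chloro with hydrogen gives a 1.0-fold lower number from compound 1 to compound 4 (0.01 log units; within the scatter), so methoxy, chloro and hydrogen at this position all read alike within the scatter. Nothing available here bears on why these three readings match.

From the compounds shown here alone, whether an amine, a carboxylic acid or a longer chain at this same position would also read alike stays open. So does whether the methoxy groups on the other ring of the shared core can be changed with as little effect on this reading.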